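Thiazolyl Carbonyl in Place of Acetyl on a Shared Core

This account rests on a few compounds, and the source may have more. Where it says the series, first, only, none or still open, it means among the compounds named here.

Of the compounds shown here, three on one shared core have been measured in an assay on HEK293 cells for agonist activity at Toll-like receptor 8 (Homo sapiens), read by a luciferase reporter, with a stated time of 6 h; a lower number here means that less compound is needed, a higher number that more compound is needed for the effect. Compound 1 `CCCCNc1nc(N)nc2c1CCNC2` carries the ring nitrogen unsubstituted and gives 0.6 uM. Compound 2 `CCCCNc1nc(N)nc2c1CN(C(C)=O)CC2` bears an acetyl on that nitrogen and gives 0.5 uM. Compound 3 `CCCCNc1nc(N)nc2c1CN(Cc1c[nH]c3ccccc13)CC2` bears a larger, ring-containing group there and gives 0.22 uM.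

Among these three numbers compound 2 stands second highest. Its nearest neighbour is compound 1, whose value lies within the usual scatter of it, so no order between the two can be read. Compound 3 is furthest away, with a lower number that sits beyond the scatter.

Compound 4 `CCCCNc1nc(N)nc2c1CN(C(=O)c1csc(C)n1)CC2` is not yet measured. It differs from compound 2 in one place: 2-methyl-1,3-thiazol-4-yl in place of methyl on a carbonyl carbon. The change enlarges the group on the carbonyl carbon while keeping the amide-type nitrogen in the ring.

Going by the values given here, since no single-point step between measured compounds is available, the expectation rests on the three values alone. A modest move toward a lower number is expected, a 1.7-fold lower number from compound 2 to compound 4 (0.22 log units; within the scatter), because compound 3 with its larger ring-bearing substituent reaches 0.22 uM. Compound 4 is therefore estimated at 0.3 uM, within a range from 0.1 uM to 0.8 uM.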

Compound 4, minimum effective concentration: 1.8 uM
Compound 4: the middle estimate sits 6.0-fold (0.78 log units) below what was measured; measured number outside the range, above it.
By their numbers in this assay, from the lowest: compound 3; then compounds 2 and 1 (each within the scatter of the next); then compound 4.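

In this assay, the change on the carbonyl carbon gives a 3.6-fold higher number from compound 2 to compound 4 (0.56 log units; beyond the scatter) and so supplies the first single-place step among these compounds. It shows that this position does not accept every larger group without cost: with an amide-type nitrogen in a ring as the other neighbour of the carbonyl carbon, exchanging methyl for 2-methyl-1,3-thiazol-4-yl means that more compound is needed for the effect, and the rise lies beyond the scatter. Nothing in the data shown accounts for this rise.

Going by these compounds, it remains open whether the rise belongs to the 2-methyl-1,3-thiazol-4-yl group as a whole or to one part of it, a question that a phenyl or an unsubstituted 1,3-thiazol-4-yl on the same carbonyl carbon could help to separate. Also open, on these data alone, is how the number responds to smaller steps away from methyl at this place, such as an ethyl, a cyclopropyl or a dimethylamino group, which would show whether the trend sets in gradually or only with a group as large as this one.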